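From phenethyl to 4-nitrobenzyl on a shared core

The source may hold more compounds than are shown below. What is called first, only, known or untested is meant among the compounds shown, and "the series" means these compounds.

Compounds in a functional assay on KMS-11 cells (Homo sapiens) for antiproliferative activity, read by CellTiter-Glo, with a stated time of 72 h (a lower number here means a stronger inhibitor, a higher number a weaker inhibitor), so far:
Compound 1 `COc1ccc(C(=O)N(Cc2ccncc2)Cc2cccc(OCCc3cccc(C(F)(F)F)c3)c2)cc1` gives 8900 nM
Compound 2 `COc1ccc(C(=O)N(Cc2ccncc2)Cc2cccc(OCCc3ccccc3)c2)cc1` gives 16900 nM
Compound 3 `COc1ccc(C(=O)N(Cc2ccncc2)Cc2cccc(OCC3CCN(C(=O)OC(C)(C)C)CC3)c2)cc1` gives 5100 nM
Compound 4 `COc1ccc(C(=O)N(Cc2ccncc2)Cc2cccc(OCc3ccc([N+](=O)[O-])cc3)c2)cc1` is still unmeasured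

In this assay compound 2 gives 16900 nM at the top of this small range of numbers. It lies within the scatter of compound 1 and clearly above compound 3 at 5100 nM on the same scale.

The change to compound 4 reads 4-nitrophenyl in place of benzyl on a saturated chain carbon bound to an oxygen on an aromatic ring and in words it is 4-nitrophenyl in place of benzyl on a saturated chain carbon bound to an oxygen on an aromatic ring. Cut one bond further out, phenethyl gives way to 4-nitrobenzyl.

Going by the values given here, only one measured step bears on this, namely a 1.9-fold higher number from compound 1 to compound 2 (0.28 log units; within the scatter) with hydrogen in place of trifluoromethyl on an aromatic carbon. Among the compounds with values here, that step stayed within the scatter, and no measured compound has the 4-nitrophenyl group, so the direction remains uncertain. Since compound 3 gives 5100 nM with a different side chain, the estimate leans only slightly downward. Expected in this assay is a 1.4-fold lower number from compound 2 to compound 4 (0.15 log units; within the scatter) and so no step beyond the scatter. The estimate for compound 4 is 12000 nM with an expected range from 5000 nM to 28000 nM overall.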

Compound 4, half-maximal inhibitory concentration: 15400 nM
Estimate against measurement, compound 4: 1.3-fold (0.11 log units) below; the measured number falls inside the stated range.
By their numbers in this assay, from the lowest: compounds 3, 1, 4 and 2 (each within the scatter of the next, the first and the last beyond it).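

In this assay, putting 4-nitrophenyl in place of benzyl on a saturated chain carbon bound to an oxygen on an aromatic ring gives a 1.1-fold lower number from compound 2 to compound 4 (0.04 log units; within the scatter), so this swap makes no difference that can be told from the usual scatter. The comparison with the 3-(trifluoromethyl)benzyl side chain gives a 1.7-fold higher number from compound 1 to compound 4 (0.24 log units; within the scatter), which means that compound 1, compound 2 and compound 4, with three different ends on this side chain, cannot be told apart in this assay. Going from phenethyl to 4-nitrobenzyl alters the chain and the ring substituent at once, and nothing available explains why the numbers stay so close.

A plain benzyl on the same oxygen would separate the effect of the chain from that of the nitro group, and the compounds shown do not settle this. Also open, on these data alone, is whether an amine or a carboxylic acid on that ring, or a longer chain, would move the number beyond the scatter.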